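Replacing Methoxy with Hydroxy-methylethyl on the Amide Aryl

The source may report more compounds than this note shows. Statements on the series, on what has been measured and on what is new or still open speak of the compounds shown alone.

Compound 1, `CNC(=O)c1cccc(S(=O)(=O)Oc2ccc(-c3cncn3C3CCN(C(=O)c4ccc(Cl)c(C(F)(F)F)c4)CC3)cc2)c1`, in an assay on THP-1 cells for antagonist activity at P2X purinoceptor 7 (Homo sapiens), read by ELISA, with a stated time of 30 min (a lower number here means a stronger inhibitor, a higher number a weaker inhibitor), gives 1.76 nM.
Compound 2, `COc1ccc(C(=O)N2CCC(n3cncc3-c3ccc(OS(=O)(=O)c4cccc5cnccc45)cc3)CC2)cc1`, in this assay gives 64 nM.
Compound 3, `O=C(c1ccc([N+](=O)[O-])cc1)N1CCC(n2cncc2-c2ccc(OS(=O)(=O)c3cccc4cnccc34)cc2)CC1`, in this assay gives 8.29 nM.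

Among these three numbers compound 2 has the highest, so it is the weakest inhibitor shown: compound 3 sits nearest, and compound 1 furthest away. Within the data shown here, the one single-point change that has been measured runs from compound 2 to compound 3, where a 7.7-fold lower number from compound 2 to compound 3 (0.89 log units; beyond the scatter) was seen for nitro in place of methoxy on an aromatic carbon.

Compound 4, `CC(C)(O)c1ccc(C(=O)N2CCC(n3cncc3-c3ccc(OS(=O)(=O)c4cccc5cnccc45)cc3)CC2)cc1`, has not yet been measured. It differs from compound 2 by 1-hydroxy-1-methylethyl in place of methoxy on an aromatic carbon. The measured step from compound 2 to compound 3 touches the same aromatic carbon and shows that this position tolerates a change of group with the number moving downward. Nitro and 1-hydroxy-1-methylethyl are different groups, so that step is only a loose guide, but it is the one that bears on this change.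

Compound 4 is therefore expected to give about 30 nM, with a range from 8 nM to 120 nM. The expected step is a 2.1-fold lower number from compound 2 to compound 4 (0.33 log units; beyond the scatter).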

Compound 4, half-maximal inhibitory concentration: 4.7 nM
Compound 4: middle estimate off by 6.4-fold (0.81 log units), on the high side, and the stated range ends above it.
By their numbers in this assay, from the lowest: compound 1; then compounds 4 and 3 (each within the scatter of the next); then compound 2.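

Putting 1-hydroxy-1-methylethyl in place of methoxy, on the aromatic carbon para to a large group, gives a 14-fold lower number from compound 2 to compound 4 (1.13 log units; beyond the scatter) in this assay and is a large step, so a second group has now lowered the number at this position and by more than the scatter. Nitro and 1-hydroxy-1-methylethyl are quite different groups, yet a 1.8-fold lower number from compound 3 to compound 4 (0.25 log units; within the scatter) means that compounds 3 and 4 cannot be told apart here, and methoxy, in compound 2, remains the group with the highest number of the three at this carbon. Nothing measured here explains why either replacement lowers the number.

On these data alone, what an isopropyl group, the same chain without its hydroxy, would give at this carbon stays open, and so do an amine and a carboxylic acid, which would show how widely the position accepts other groups. As far as these compounds go, compound 1 differs from these compounds in more than one place, so whether the same swap would lower the number on the core of compound 1 also remains open.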